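A few compounds are considered here, and "the series" means these few. Any claim that something is new, unique, unknown or untested is made for them only; others in the source may bear on it.

Compound 1, `CC1=C(C(=O)OCc2ccccc2)C(c2ccc(-c3ccccc3)cc2)NC(=S)N1Cc1ccc(-c2nnn[nH]2)cc1`, gives 140000 nM in a toxicity assay on MCF7 cells (Homo sapiens) for inhibition, with a stated time of 48 h; a higher number here means a weaker inhibitor of growth, a lower number a stronger inhibitor of growth. Compound 2, `CC1=C(C(=O)OCc2ccccc2)C(c2ccc(-c3ccccc3C)cc2)NC(=S)N1CCCCCc1nnn[nH]1`, gives "not determined" (no result reported) in this assay.

Compound 2 therefore stands nowhere on this scale: no single number is known for it. Compound 3, `CC1=C(C(=O)OCc2ccccc2)C(c2ccc(-c3ccccc3C)cc2)NC(=S)N1Cc1ccc(-c2nnn[nH]2)cc1`, differs from compound 2 by 4-(1H-tetrazol-5-yl)phenyl in place of 4-(1H-tetrazol-5-yl)butyl on a saturated chain carbon bound to an amide-type nitrogen in a ring. Among the measured compounds shown here, with no result for compound 2 and no step between measured compounds in this assay, the size and direction of the change cannot be read from the data. Compound 3 is expected to be a weak inhibitor of growth because compound 1 gives 140000 nM in this assay. The estimate for compound 3 is 120000 nM, with a range from 40000 nM to 400000 nM.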

Compound 3, concentration for 50% growth inhibition: 160000 nM
Beside the measured number, compound 3's estimate is 1.3-fold (0.12 log units) below it, within the range that was stated.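

In this assay, methyl in place of hydrogen on an aromatic carbon gives a 1.1-fold higher number from compound 1 to compound 3 (0.06 log units; within the scatter) and so, at this position, a methyl group does not move the number beyond the scatter. No measured finding offered here accounts for this result. With no number for compound 2, the difference between 5-(1H-tetrazol-5-yl)pentyl and 4-(1H-tetrazol-5-yl)benzyl cannot be read. The compounds shown leave open whether a methoxy group or a chlorine atom on that aromatic carbon would behave as methyl does, and whether a carboxylic acid in place of the 1H-tetrazol-5-yl group would shift the number.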